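The compounds below may be only part of what the source reports. "The series", "measured", "known", "first", "only" and "open" are said of these compounds alone.

Compound 1 `Nc1sc(-c2ccc(Cl)cc2)c(-c2ccc(Cl)cc2)c1C(=O)NC1CCCCC1`: 2410 nM
Compound 2 `CCOC(=O)Nc1sc(-c2ccc(Cl)cc2)c(-c2ccc(Cl)cc2)c1C(=O)NC1CC1`: 39800 nM

In a functional assay on A549 cells (Homo sapiens) for inhibition, read by sulforhodamine B assay, with a stated time of 72 h (on this read-out higher numbers stand for weaker inhibition and lower numbers for stronger inhibition), compound 1 gives 2410 nM, the lower of the two numbers and clearly apart from compound 2 at 39800 nM. Compound 3 `CC(C)(C)NC(=O)c1c(N)sc(-c2ccc(Cl)cc2)c1-c1ccc(Cl)cc1` has tert-butyl in place of cyclohexyl on an amide-type nitrogen. Going by the values given here, no measured pair shows this change on its own, so the expectation is a cautious one. In this assay, a modest rise in the number is expected, estimated as a 1.7-fold higher number from compound 1 to compound 3 (0.22 log units; within the scatter), and it may stay within the usual scatter. For compound 3, the estimated value is 4000 nM, with an expected range of 1500 nM to 12000 nM.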

Compound 3, half-maximal inhibitory concentration: 8850 nM
The estimate for compound 3 lay 2.2-fold (0.34 log units) below the measured number; the range from low to high includes it.
By their numbers in this assay, from the lowest: compound 1; then compound 3; then compound 2.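

In this assay, going by these compounds alone, this is the first comparison that changes only the group on the amide-type nitrogen: tert-butyl in place of cyclohexyl gives a 3.7-fold higher number from compound 1 to compound 3 (0.56 log units; beyond the scatter) and so weaker inhibition. The result shows that this position responds to the change, even though both groups contain only carbon and have no hydrogen-bond donors or acceptors. No measurement here explains the rise.

As far as these compounds go, whether the ring itself matters remains open, and a straight butyl chain or cyclopentyl on this nitrogen could help test that. Compound 2 differs from compound 1 in more than one place, so it cannot settle the question.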